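The source may hold more compounds than are shown below. What is called first, only, known or untested is meant among the compounds shown, and "the series" means these compounds.

Working notes on the series. Compound 1 `CCN(CC)S(=O)(=O)c1ccc(S(=O)(=O)N2CCC[C@@H](C(=O)N3CCC(O)CC3)C2)cc1` gives 870 nM in a functional assay on MIA PaCa-2 cells (Homo sapiens) for inhibition, read by MTT assay, with a stated time of 7 days (on this read-out lower numbers stand for stronger inhibition and higher numbers for weaker inhibition), and stands as the higher of the two numbers recorded so far. Compound 2 `O=C([C@@H]1CCCN(S(=O)(=O)c2ccc(S(=O)(=O)C3CCC3)cc2)C1)N1CCC(F)(F)CC1` gives 9 nM in this assay; it differs from compound 1 in more than one place, so only the two values themselves are compared here. Compound 3 `CCN(CC)S(=O)(=O)c1ccc(S(=O)(=O)N2CCC[C@@H](C(=O)N3CCC(COC)CC3)C2)cc1` is the next entry, made from compound 1 by methoxymethyl in place of hydroxy on a saturated ring carbon and not yet measured. Within the data shown here, no single-site step of this kind is recorded, so only a small change, if any beyond the scatter, is expected for compound 3 as a 1.5-fold lower number from compound 1 to compound 3 (0.16 log units; within the scatter). Compound 3 is estimated at 600 nM, with a range from 200 nM to 2000 nM.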

Compound 3, half-maximal inhibitory concentration: 250 nM
The estimate for compound 3 lay 2.4-fold (0.38 log units) above the measured number; measured number inside the range.
By their numbers in this assay, from the lowest: compound 2; then compound 3; then compound 1.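

Among these compounds, on the saturated ring carbon, three ring bonds from the ring nitrogen, methoxymethyl in place of hydroxy gives a 3.5-fold lower number from compound 1 to compound 3 (0.54 log units; beyond the scatter), the first single-site step and one beyond the scatter. The hydrogen-bond donor of compound 1 is therefore not required for activity at this position, and the larger group is accepted. No available measurement explains the step. Going by these compounds, whether the ether oxygen or the added carbons carry the change stays open, as does how an amine, a carboxylic acid or a longer alkoxyalkyl chain would read at this carbon.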